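This account rests on a few compounds, and the source may have more. Where it says the series, first, only, none or still open, it means among the compounds named here.

Compound 1 `COc1cc2nc(N3CCC[C@@H](N)C3)nc(N)c2cc1OC` — in an assay on CHO cells for displacement of a labelled ligand from Alpha-1A adrenergic receptor (Homo sapiens), with a stated time of 30 min (on this read-out higher numbers stand for weaker inhibition and lower numbers for stronger inhibition), compound 1 reaches only the assay limit, > 1000 nM.
Compound 2 `COc1cc2nc(N3CCC[C@H](N)C3)nc(N)c2cc1OC` — in this assay compound 2 gives 191 nM.

Compound 1 therefore stands at the limit, the weaker of the two values shown, and the step of an at least 5.2-fold lower number from compound 1 to compound 2 (0.71 log units; beyond the scatter) shows the configuration drawn in compound 2 giving the stronger binding. Compound 3 `COc1cc2nc(N3CCC[C@@H](NC(=O)c4ccco4)C3)nc(N)c2cc1OC` differs from compound 1 by (furan-2-yl)carbonyl in place of hydrogen on an amine nitrogen. Among the compounds with values here, no measured step touches this nitrogen; the one measured step changes configuration alone, so it offers no direct guide to the new amide. For compound 3 an improvement is nonetheless expected, estimated as an at least 25-fold lower number from compound 1 to compound 3 (1.39 log units; beyond the scatter). Compound 3 is estimated at 40 nM, with a range from 4 nM to 400 nM.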

Compound 3, inhibition constant: 110 nM
Compound 3: the middle estimate sits 2.8-fold (0.44 log units) below what was measured, within the range that was stated.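

Compound 1 stands at a limit of the assay (> 1000 nM). Within the data shown here, putting (furan-2-yl)carbonyl in place of hydrogen on the amine nitrogen, a place the earlier compounds left unchanged, gives an at least 9.0-fold lower number from compound 1 to compound 3 (0.95 log units; beyond the scatter) in this assay, so binding with the configuration drawn in compound 1 can be brought off the limit by a change at this nitrogen. From the compounds shown here alone, the true size of the step stays unknown because of this fact: the limit of > 1000 nM in this assay, at which 1 of the 3 values shown sits.

Going by these compounds, whether the same amide would shift binding in the same way with the configuration of compound 2 stays open. So does the part played by the furan ring, which an acetyl or benzoyl group on this nitrogen would help to separate from that of the carbonyl.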